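This account rests on a few compounds, and the source may have more. Where it says the series, first, only, none or still open, it means among the compounds named here.

Measured compounds:
- compound 1, `Cc1nc(SCC(=O)Nc2nc(-c3ccc(Cl)cc3)cs2)n(Nc2ccccc2)c1C`: 2600 nM
- compound 2, `Cc1ccc(Nn2c(SCC(=O)Nc3nc(-c4ccccc4)cs3)nc(C)c2C)cc1`: 3040 nM

Of the compounds shown here, two have been tested in a functional assay on NCI/ADR-RES cells (Homo sapiens) for antiproliferative activity, read by sulforhodamine B assay, with a stated time of 48 h; a lower number here means a stronger inhibitor of growth, a higher number a weaker inhibitor of growth. Compound 1 gives 2600 nM and holds the lowest of the two numbers. Compound 2, which differs from it in two places at once, gives 3040 nM in this assay; the two values sit close together, within the scatter of the measurement, so neither can be called the more potent of the pair.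

Compound 3, `COc1ccc(Nn2c(SCC(=O)Nc3nc(-c4ccc(Cl)cc4)cs3)nc(C)c2C)cc1`, has not yet been measured. It keeps the whole frame of compound 1 and differs from it in one spot: methoxy in place of hydrogen on an aromatic carbon. Among the measured compounds shown here, no pair among the measured compounds shows the effect of a single change of this kind, so there is no step to lean on. The two measured values lie so near each other that a modest change at the edge of the molecule is not expected to move the number beyond the scatter in either direction. Compound 3 is therefore expected to give about 2500 nM in this assay, within the range 1000 nM to 6500 nM. The estimated step of a 1.0-fold lower number from compound 1 to compound 3 (0.02 log units; within the scatter) is expected to be small.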

Compound 3, concentration for 50% growth inhibition: 2890 nM
For compound 3 the middle estimate is 1.2-fold (0.06 log units) below the measured one; the measured number falls inside the stated range.
By their numbers in this assay, from the lowest: compounds 1, 3 and 2 (each within the scatter of the next).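

In this assay, the anilino ring of compound 1 becomes (4-methoxyphenyl)amino in compound 3, with methoxy replacing hydrogen on an aromatic carbon para to a large group, and this gives a 1.1-fold higher number from compound 1 to compound 3 (0.05 log units; within the scatter). Among the compounds shown here, this is the first single-change step available, and it shows that compound 1 and compound 3 cannot be told apart in this measurement: at this position, adding methoxy, with its 2 heavy atoms and 1 hydrogen-bond acceptor, leaves no readable effect on growth inhibition. No measured evidence bears on why this is so.

This single pair cannot show whether the position would accept other groups equally well, such as an amine, a carboxylic acid or a longer chain such as butoxy, or whether one of them would move the number beyond the scatter. The compounds shown also offer no single-change step anywhere else on the molecule, so what the other parts of the shared frame contribute to activity remains open.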